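Removing a methyl from the fused core of compound 3

A few compounds are considered here, and "the series" means these few. Any claim that something is new, unique, unknown or untested is made for them only; others in the source may bear on it.

The series shares an amide-linked oxane alcohol on a bicyclic core carrying a benzyl group. Compound 1 `O=C(N[C@H]1CCOC[C@@H]1O)c1cn(Cc2ccc(-n3cccn3)cc2)c2cccnc12` bears a pyrazolyl on the benzyl ring, while compound 2 `Cc1ccc2c(n1)c(C(=O)N[C@H]1CCOC[C@@H]1O)cn2Cc1ccc(-c2ccn(C)n2)cc1` and compound 3 `Cc1cnc2c(C(=O)N[C@H]3CCOC[C@@H]3O)cn(Cc3ccc(-c4ccn(C)n4)cc3)c2c1` carry a methylpyrazolyl together with a methyl at different points of the fused core. In an ADME assay on liver for metabolic stability, with Liver microsome (Homo sapiens) as the target, using microsomes (on this read-out higher numbers stand for fast clearance and lower numbers for slow clearance), compound 1 gives < 8 mL/min/kg, which is a limit of the assay rather than a number. In this assay compound 2 likewise gives < 8 mL/min/kg, again a limit. For the measured compounds named here, compound 3 is the only member with an actual number, giving 2.5 mL/min/kg in this assay, so it stands as the one measured point among values that otherwise sit at the limit of < 8 mL/min/kg in this assay, at which 2 of the 3 values shown sit. Going by the values given here, no two measured compounds differ in a single place, so no measured step is available.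

Compound 4 `Cn1ccc(-c2ccc(Cn3cc(C(=O)N[C@H]4CCOC[C@@H]4O)c4ncccc43)cc2)n1` differs from compound 3 by hydrogen in place of methyl on an aromatic carbon. The step from compound 3 to compound 4 is expected to be a 1.6-fold higher number from compound 3 to compound 4 (0.20 log units; within the scatter), a change that should stay within the usual scatter. Compound 4 is therefore expected to give about 4 mL/min/kg in this assay, within a range from 1.5 mL/min/kg to 10 mL/min/kg.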

Compound 4, clearance: 10.6 mL/min/kg
Beside the measured number, compound 4's estimate is 2.7-fold (0.42 log units) below it; the measured number lies above the stated range.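

In this assay, for the compounds shown here, the methyl on the aromatic carbon two atoms from the ring nitrogen now has a measured step: hydrogen in its place gives a 4.2-fold higher number from compound 3 to compound 4 (0.63 log units; beyond the scatter), so at this position the change reaches beyond the scatter, which none of the earlier compounds could show. The other two steps give only floors: hydrogen in place of methyl on an aromatic carbon gives an at least 1.3-fold higher number from compound 2 to compound 4 (0.12 log units; that floor lies within the scatter), and 1-methyl-1H-pyrazol-3-yl in place of 1H-pyrazol-1-yl on an aromatic carbon gives an at least 1.3-fold higher number from compound 1 to compound 4 (0.12 log units; that floor lies within the scatter). Neither of these can be sized, because each starts from a limit of the assay and not from a number: the limit of < 8 mL/min/kg in this assay, at which 2 of the 4 values shown sit.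

The compounds shown leave open whether another group on this carbon, such as ethyl, methoxy or a fluorine atom, would keep the lower number seen with methyl or give a number closer to that of hydrogen. They also leave open how large the true steps to compound 4 are from compound 1 and from compound 2.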